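The source may hold more compounds than are shown below. What is called first, only, known or untested is meant among the compounds shown, and "the series" means these compounds.

Of the compounds shown here, three have been measured in an assay for inhibition of HSP60/HSP10 (Homo sapiens), with a stated time of 60 min; on this read-out higher numbers stand for weaker inhibition and lower numbers for stronger inhibition. Compound 1 `O=C(Nc1cccc(Cl)c1)c1cc(Br)cc(Br)c1` reaches only the limit of the assay, > 100000 nM, not a number. Compound 3 `COc1ccccc1C(=O)Nc1ccccc1` likewise gives only the limit > 100000 nM. Going by the values given here, compound 2 `O=C(Nc1ccc(Sc2nc3ccccc3s2)c(Cl)c1)c1cccc(Br)c1O` is the one compound with an actual number, giving 6900 nM in this assay, so it stands alone against the two others, which sit at the limit of > 100000 nM in this assay, at which 2 of the 3 values shown sit.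

Compound 4 `COc1c(Br)cccc1C(=O)Nc1ccc(Sc2nc3ccccc3s2)c(Cl)c1` differs from compound 2 by a single change: methyl in place of hydrogen on an oxygen on an aromatic ring, or hydroxy to methoxy when read one bond further out. Among the compounds with values here, no measured pair shows this change. The step from compound 2 to compound 4 is expected to weaken inhibition beyond the scatter, estimated as a 3.6-fold higher number from compound 2 to compound 4 (0.56 log units; beyond the scatter). Compound 4 is accordingly expected to give about 25000 nM, within a range from 7000 nM to 90000 nM, in this assay.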

Compound 4, half-maximal inhibitory concentration: > 100000 nM
Compound 4 ended at the assay's limit (the forecaster's own chance of this, stated with the estimate: 25%); middle value at least 4.0-fold (0.60 log units) away from the limit.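

The change from hydroxy to methoxy gives an at least 14-fold higher number from compound 2 to compound 4 (1.16 log units; beyond the scatter), the first step seen at this position, and it shows that inhibition at this place does not tolerate methyl on the oxygen. Compound 4 gives only a limit, so the step has a bound on one side only, and compound 2 remains the one compound with an actual number: the limit of > 100000 nM in this assay, at which 3 of the 4 values shown sit.

On these data alone, what an amine or a carboxylic acid in place of the hydroxy would give stays open. As far as these compounds go, whether the lost hydrogen or the added methyl carries the step also stays open.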